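The compounds below may be only part of what the source reports. "The series", "measured", "known", "first", "only" and "open" are said of these compounds alone.

Measured so far:

Compound 1, `O=c1[nH]c(=S)ccn1[C@@H]1O[C@H](COP(=O)(O)O)[C@@H](O)[C@H]1O`: in an in vitro functional assay on 1321-N1 cells for agonist activity at P2Y purinoceptor 6 (Homo sapiens), read by scintillation proximity assay and inositol phosphate accumulation (on this read-out higher numbers stand for an effect only at larger amounts of compound and lower numbers for an effect already at smaller amounts), compound 1 gives > 100000 nM, a limit of the assay rather than a number.
Compound 2, `CSc1nc(=O)ccn1[C@@H]1O[C@H](COP(=O)(O)OP(=O)(O)O)[C@@H](O)[C@H]1O`: in this assay compound 2 gives 4700 nM.
Compound 3, `O=c1ccn([C@@H]2O[C@H](COP(=O)(O)O)[C@@H](O)[C@H]2O)c(SCc2ccccc2)n1`: in this assay compound 3 gives > 100000 nM, again a limit of the assay and not a number.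

Among the measured compounds shown here, compound 2 therefore stands as the only compound of the three with a number in this assay; the other two values are limits, as the limit of > 100000 nM in this assay, at which 2 of the 3 values shown sit, shows. For the measured compounds named here, no step between two measured compounds differs in a single place, so no measured step can be drawn on.

Compound 4, `CNc1nc(=O)ccn1[C@@H]1O[C@H](COP(=O)(O)OP(=O)(O)O)[C@@H](O)[C@H]1O`, is not yet measured. It differs from compound 2 in one place: methylamino in place of methylsulfanyl on an aromatic carbon. Going by the values given here, no measured pair speaks to this exchange, so the expectation for compound 4 rests on compound 2 alone. The step of a 2.1-fold higher number from compound 2 to compound 4 (0.33 log units; beyond the scatter) is expected to be small, toward weaker activity but possibly within the scatter. Compound 4 is estimated at 10000 nM in this assay, within 2000 nM to 50000 nM.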

Compound 4, half-maximal effective concentration: > 100000 nM
Compound 4: only a limit was reported; the forecaster's own chance of this, stated with the estimate: 15%; middle value at least 10-fold (1.00 log units) from the limit.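

In this assay, methylamino in place of methylsulfanyl on an aromatic carbon between two ring nitrogen atoms gives an at least 21-fold higher number from compound 2 to compound 4 (1.32 log units; beyond the scatter), so this position does not accept every small group of the same heavy-atom count, and this exchange, which also adds a hydrogen-bond donor, is not a neutral one. The value of compound 4, > 100000 nM, is a limit of the assay and not a number. Compound 2 remains the only compound of the four with a number, the other three resting at one shared value: the limit of > 100000 nM in this assay, at which 3 of the 4 values shown sit.

On these data alone, it remains open whether a longer chain such as ethylsulfanyl, or a methoxy group or a free amine, would keep a number at this position in this assay. Compound 1 and compound 3 differ from compound 2 in more than one place, so the group on this carbon and the phosphate chain cannot be separated.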